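A few compounds are considered here, and "the series" means these few. Any claim that something is new, unique, unknown or untested is made for them only; others in the source may bear on it.

Measured so far:
- compound 1, `COc1ccc(CN(C(=O)CCl)c2cc(OC)c(OC)c(OC)c2)cc1O`: 250 nM
- compound 2, `COc1ccc(CNc2cc(OC)c(OC)c(OC)c2)cc1F`: 32200 nM
- compound 3, `COc1cc(NCc2ccc(Cl)cc2)cc(OC)c1OC`: > 80000 nM

All three were tested in a functional assay on HCT-116 cells (Homo sapiens) for inhibition, read by MTT assay, with a stated time of 48 h; a higher number here means a weaker inhibitor, a lower number a stronger inhibitor. Compound 1 gives 250 nM, the lowest of the two numbers recorded. Compound 2 gives 32200 nM, a gap from compound 1 far beyond the usual scatter. For compound 3 the assay reports only a limit, > 80000 nM, not a number; this is the limit of > 80000 nM in this assay, at which 1 of the 3 values shown sits.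

Compound 4, `COc1ccc(CN(C(=O)C(C)Br)c2cc(OC)c(OC)c(OC)c2)cc1O`, has not yet been measured in this assay. It differs from compound 1 in one place: 1-bromoethyl in place of chloromethyl on a carbonyl carbon. The acyl group on the amide-type nitrogen changes from (chloromethyl)carbonyl to (1-bromoethyl)carbonyl; the rest of the shared core is unchanged.

Among the compounds with values here, no step between two measured compounds of this kind is recorded, so the expectation rests on compound 1 alone. A modest change is expected, most likely toward a slightly higher number, with a step from compound 1 to compound 4 of about a 2.4-fold higher number from compound 1 to compound 4 (0.38 log units; beyond the scatter). Compound 4 is therefore estimated at 600 nM in this assay, within a range from 120 nM to 4000 nM.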

Compound 4, half-maximal inhibitory concentration: 140 nM
Compound 4: middle estimate off by 4.3-fold (0.63 log units), on the high side, within the range that was stated.
By their numbers in this assay, from the lowest: compounds 4 and 1 (each within the scatter of the next); then compound 2. At a limit, above all of these: compound 3.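

In this assay, putting 1-bromoethyl in place of chloromethyl on the carbonyl carbon gives a 1.8-fold lower number from compound 1 to compound 4 (0.25 log units; within the scatter), so compound 1 and compound 4 cannot be told apart. Within the data shown here, this is the first direct reading at this position, and it shows that the site tolerates this swap of halogen together with the added carbon, with the number staying in the same range. Nothing measured here offers an explanation for that result.

Bromine and the added carbon enter together in compound 4, so their separate contributions remain open. Also open, as far as these compounds go, is whether a halogen is needed at all at this position, which a plain ethyl group or a dimethylamino group on the same carbonyl carbon would help to settle.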